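Swapping the aryl group on the amide of compound 3

The source may hold more compounds than are shown below. What is called first, only, known or untested is meant among the compounds shown, and "the series" means these compounds.

Measured in a functional assay on HT-29 cells (Homo sapiens) for cytotoxicity, read by MTT assay, with a stated time of 72 h; a higher number here means a weaker inhibitor, a lower number a stronger inhibitor:
- compound 1 `COc1ccc(NC(=O)CN2CCN(c3nnc(Cc4ccncc4)c4ccccc34)CC2)cc1OC` gives 40100 nM
- compound 2 `Cc1ccc(NC(=O)CN2CCN(c3nnc(Cc4ccncc4)c4ccccc34)CC2)c(C)c1` gives 1930 nM
- compound 3 `O=C(CN1CCN(c2nnc(Cc3ccncc3)c3ccccc23)CC1)Nc1cccc(F)c1` gives 6130 nM

Compound 3 stands in the middle of these three numbers. Compound 4 `O=C(CN1CCN(c2nnc(Cc3ccncc3)c3ccccc23)CC1)Nc1ccc(F)c(C(F)(F)F)c1` differs from it in one place, on an amide-type nitrogen: 4-fluoro-3-(trifluoromethyl)phenyl in place of 3-fluorophenyl on an amide-type nitrogen. Three measured swaps at that same place bear on this change. They are a 6.5-fold lower number from compound 1 to compound 3 (0.82 log units; beyond the scatter), a 3.2-fold higher number from compound 2 to compound 3 (0.50 log units; beyond the scatter) and a 21-fold lower number from compound 1 to compound 2 (1.32 log units; beyond the scatter), all beyond the scatter. None of them brings in the new group, so they show that this place matters but fix no direction. A modest step is expected in this assay, estimated as a 1.8-fold lower number from compound 3 to compound 4 (0.24 log units; within the scatter), with only a slight lean to a lower number since compound 2 already reaches lower (1930 nM). Compound 4 is estimated at 3500 nM, with an expected range from 900 nM to 14000 nM.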

Compound 4, half-maximal inhibitory concentration: 1110 nM
Beside the measured number, compound 4's estimate is 3.2-fold (0.50 log units) above it; the range from low to high includes it.
By their numbers in this assay, from the lowest: compounds 4 and 2 (each within the scatter of the next); then compound 3; then compound 1.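

In this assay, 4-fluoro-3-(trifluoromethyl)phenyl in place of 3-fluorophenyl gives a 5.5-fold lower number from compound 3 to compound 4 (0.74 log units; beyond the scatter) on the amide nitrogen, so this place accepts an aryl group with more heavy atoms and more fluorine without a loss. Two quite different aryl groups now match, as a 1.7-fold lower number from compound 2 to compound 4 (0.24 log units; within the scatter) shows, while the 3,4-dimethoxyphenyl group stays well apart, with a 36-fold lower number from compound 1 to compound 4 (1.56 log units; beyond the scatter) for this change. No measurement shown explains these steps. Still open, on these data alone, is how an amine or a carboxylic acid on the ring would fare, and whether trifluoromethyl without the fluorine would give the same step.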